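From Trifluoromethyl to Methyl on the Shared Core

A few compounds are considered here, and "the series" means these few. Any claim that something is new, unique, unknown or untested is made for them only; others in the source may bear on it.

Compound 1 `Clc1ccc(-c2nn(-c3ccccc3)cc2-c2nc3cc(Br)ccc3[nH]2)cc1`: 1920 nM
Compound 2 `FC(F)(F)c1ccc2[nH]c(-c3cn(-c4ccccc4)nc3-c3ccc(Cl)cc3)nc2c1`: 4210 nM

Within the data shown here, in a functional assay on MCF7 cells (Homo sapiens) for antiproliferative activity, read by MTT assay, with a stated time of 48 h (on this read-out lower numbers stand for stronger inhibition and higher numbers for weaker inhibition), compound 2 gives 4210 nM, the higher of the two numbers measured so far, which makes it the weaker inhibitor of the pair. Among the measured compounds shown here, the only measured step is a 2.2-fold higher number from compound 1 to compound 2 (0.34 log units; beyond the scatter), with trifluoromethyl in place of bromo on an aromatic carbon. Compound 3 `Cc1ccc2[nH]c(-c3cn(-c4ccccc4)nc3-c3ccc(Cl)cc3)nc2c1` comes next, and the change is methyl in place of trifluoromethyl on an aromatic carbon. For the measured compounds named here, no measured compound carries methyl, so the data offer no direct reading of this group. Compound 2 has just one step to guide the expectation, and that step, a 2.2-fold higher number from compound 1 to compound 2 (0.34 log units; beyond the scatter), is modest. A small move toward a lower number is therefore expected in this assay, and it may well stay within the scatter. The expected change is a 1.6-fold lower number from compound 2 to compound 3 (0.21 log units; within the scatter). Compound 3 is estimated at 2600 nM, with an expected range from 1100 nM to 6500 nM.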

Compound 3, half-maximal inhibitory concentration: 8230 nM
The estimate for compound 3 lay 3.2-fold (0.50 log units) below the measured number, outside the stated range (above it).
By their numbers in this assay, from the lowest: compound 1; then compounds 2 and 3 (each within the scatter of the next).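

In this assay the exchange of trifluoromethyl for methyl on this aromatic carbon gives a 2.0-fold higher number from compound 2 to compound 3 (0.29 log units; within the scatter) and so does not separate the two groups, although they differ in size by the heavy atoms counted for them. The new comparison with bromo is clearer, with a 4.3-fold higher number from compound 1 to compound 3 (0.63 log units; beyond the scatter) on the same position, so that compound 1 now stands apart from both compound 2 and compound 3 as the strongest inhibitor of the three, and the position responds to at least one exchange of group. Nothing available here accounts for bromo standing apart from trifluoromethyl and methyl.

From the compounds shown here alone, whether another halogen such as chloro or fluoro would stay close to bromo on this carbon remains open. So does the reading for an amine, a methoxy group or a carboxylic acid in the same place, and with only three groups compared no trend across this position can yet be claimed.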